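Chain-end amine swaps on a shared core

This account rests on a few compounds, and the source may have more. Where it says the series, first, only, none or still open, it means among the compounds named here.

Measured in a functional assay on A549 cells (Homo sapiens) for antiproliferative activity, read by MTT assay, with a stated time of 72 h; a higher number here means a weaker inhibitor, a lower number a stronger inhibitor:
- compound 1 `C/C=C/C(=O)Nc1cc2c(N3CCCc4ccccc43)ncnc2cc1OC`: 8190 nM
- compound 2 `CC/C=C/C(=O)Nc1cc2c(N3CCCc4ccccc43)ncnc2cc1OC`: 5030 nM
- compound 3 `CCN(CC)C/C=C/C(=O)Nc1cc2c(N3CCCc4ccccc43)ncnc2cc1OC`: 6410 nM

Compound 3 stands second highest of the three numbers; its nearest neighbour is compound 2, with a 1.3-fold higher number from compound 2 to compound 3 (0.11 log units; within the scatter), and the step of a 1.3-fold lower number from compound 1 to compound 3 (0.11 log units; within the scatter) is also within the scatter, as is a 1.6-fold lower number from compound 1 to compound 2 (0.21 log units; within the scatter). No chain-end change in this set has moved the number beyond the scatter.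

Compound 4 `COc1cc2ncnc(N3CCCc4ccccc43)c2cc1NC(=O)/C=C/CN1CCCCC1` differs from compound 3 by piperidin-1-yl in place of diethylamino on a saturated chain carbon bound to a double-bonded chain carbon. The steps from compound 1 and compound 2 to compound 3 bear on this; both were within the scatter. For compound 4 a step of a 1.1-fold lower number from compound 3 to compound 4 (0.03 log units; within the scatter) in this assay is therefore expected, not beyond the scatter in either direction. Compound 4 is estimated at 6000 nM, with a range of 2500 nM to 14000 nM.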

Compound 4, half-maximal inhibitory concentration: 2880 nM
For compound 4 the middle estimate is 2.1-fold (0.32 log units) above the measured one, within the range that was stated.
By their numbers in this assay, from the lowest: compounds 4, 2, 3 and 1 (each within the scatter of the next, the first and the last beyond it).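

In this assay, for the compounds shown here, piperidin-1-yl on this saturated chain carbon gives the first chain-end step beyond the scatter, a 2.2-fold lower number from compound 3 to compound 4 (0.35 log units; beyond the scatter), so the form of the amine counts here. Against hydrogen the same group gives a 2.8-fold lower number from compound 1 to compound 4 (0.45 log units; beyond the scatter), but against methyl only a 1.7-fold lower number from compound 2 to compound 4 (0.24 log units; within the scatter), which leaves piperidin-1-yl not set apart from methyl. Nothing at hand explains the difference between the two amines.

Open, on these data alone, is how a pyrrolidin-1-yl or morpholin-4-yl group at this carbon would compare with piperidin-1-yl. Also open, as far as these compounds go, is whether the closed ring itself carries the step from diethylamino.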